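A few compounds are considered here, and "the series" means these few. Any claim that something is new, unique, unknown or untested is made for them only; others in the source may bear on it.

Measured in a functional assay on LNCaP cells (Homo sapiens) for antiproliferative activity; on this read-out lower numbers stand for stronger inhibition and higher numbers for weaker inhibition:
- compound 1 `C=CC[C@@H]1C[C@@H](c2ccc(Cl)c(Cl)c2)[C@H](NC(=O)c2cc(-c3c(Cl)cnn3C)c(Cl)o2)CN1`: 160 nM
- compound 2 `Cn1ncc(Cl)c1-c1cc(C(=O)N[C@@H]2CN[C@H](CC(=O)NC3CC3)C[C@H]2c2ccc(Cl)c(Cl)c2)oc1Cl`: 190 nM

Going by the values given here, compound 2, at 190 nM, stands within the scatter of compound 1, the only other measured compound. Compound 3 `Cn1ncc(Cl)c1-c1cc(C(=O)N[C@@H]2CN[C@H](CCN3CCCC3)C[C@H]2c2ccc(Cl)c(Cl)c2)oc1Cl` follows from compound 2 by (pyrrolidin-1-yl)methyl in place of cyclopropylcarbamoyl on a saturated chain carbon bound to a saturated ring carbon. Among the compounds with values here, the sole measured step at this place, a 1.2-fold higher number from compound 1 to compound 2 (0.07 log units; within the scatter), gives little guidance, and no measured compound carries a (pyrrolidin-1-yl)methyl group. The expected step is a 1.1-fold lower number from compound 2 to compound 3 (0.02 log units; within the scatter), with no shift beyond the scatter expected in this assay. The estimate for compound 3 is 180 nM, with an expected range of 70 nM to 460 nM.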

Compound 3, half-maximal inhibitory concentration: 1920 nM
Compound 3: the middle estimate sits 11-fold (1.03 log units) below what was measured; the measured number lies above the stated range.
By their numbers in this assay, from the lowest: compounds 1 and 2 (each within the scatter of the next); then compound 3.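

In this assay, the saturated chain carbon bound to a saturated ring carbon does not tolerate every substituent: vinyl and cyclopropylcarbamoyl read alike, but (pyrrolidin-1-yl)methyl gives a 10-fold higher number from compound 2 to compound 3 (1.00 log units; beyond the scatter) and a 12-fold higher number from compound 1 to compound 3 (1.08 log units; beyond the scatter) as well. The series therefore shows its first clear sensitivity at this place. No measurement on hand explains this difference.

On these data alone, it remains open whether the pyrrolidine ring, its nitrogen or the length of the 2-(pyrrolidin-1-yl)ethyl chain drives the change. A dimethylamine, a shorter aminomethyl chain or a carboxylic acid at this place would help separate these readings.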